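The source may hold more compounds than are shown below. What is called first, only, known or untested is meant among the compounds shown, and "the series" means these compounds.

Compound 1, `CC(C)CN(c1ccc(F)cc1)S(=O)(=O)c1ccc2c(c1)C(O)CC(C1CCOCC1)O2`, is the lower of the two compounds measured in a physicochemical assay for lipophilicity, at pH 7.4 (on this read-out higher numbers stand for higher lipophilicity and lower numbers for lower lipophilicity), where compound 1 gives 3.39. Its nearest measured neighbour is compound 2, `CCc1ccc(N(CC(C)C)S(=O)(=O)c2ccc3c(c2)C(O)C[C@H](C2CCOCC2)O3)cc1`, which differs in the group on the sulfonamide nitrogen and gives 4.12, a gap that lies beyond the usual scatter of this measurement. Compound 3, `CC(C)CN(c1cc2ccccc2s1)S(=O)(=O)c1ccc2c(c1)C(O)CC(C1CCOCC1)O2`, has not yet been measured. Against compound 1 it shows one change: 1-benzothiophen-2-yl in place of 4-fluorophenyl on a sulfonamide nitrogen. Nothing measured shows this exact exchange, so the expectation rests on the general direction seen with compound 2. A sizeable rise in this assay is expected, with the step of a number 0.91 log units higher from compound 1 to compound 3 (beyond the scatter) judged to lie beyond the scatter. Compound 3 is accordingly estimated at 4.3, within a range from 3.8 to 4.8.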

Compound 3, distribution coefficient: 3.92
Estimate against measurement, compound 3: 0.38 log units above; the range from low to high includes it.
By their numbers in this assay, from the lowest: compound 1; then compounds 3 and 2 (each within the scatter of the next).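

In this assay, among these compounds, with only the group on the sulfonamide nitrogen changed, 1-benzothiophen-2-yl in place of 4-fluorophenyl gives a number 0.53 log units higher from compound 1 to compound 3 (beyond the scatter) and so provides the first clean reading at this position. The position does respond to an exchange of one aromatic group for another, although the step is only modest, even with a second aromatic ring and a sulfur atom entering. Nothing measured here accounts for the size of this step.

The compounds shown leave open whether the second ring or the sulfur atom matters more, a question that a thiophen-2-yl or a naphthalen-2-yl group at the same place could help to separate. From the compounds shown here alone, how this read-out would respond to a non-aromatic group there, such as a cyclohexyl ring or a chain carrying an amine, also remains unknown.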